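This account rests on a few compounds, and the source may have more. Where it says the series, first, only, none or still open, it means among the compounds named here.

Measured so far:
Compound 1, `Cc1n[nH]c(C(=O)O)c1Cc1ccccc1-c1ccc(F)cc1`: 73%
Compound 2, `Cc1n[nH]c(C(=O)O)c1Cc1ccc(C(F)(F)F)cc1`: 71%

Both compounds share a core carrying a carboxylic acid and a methyl group, and differ only in the substituted ring attached through a single carbon. In an assay on isolated protein for inhibition of 2-Hydroxyacid oxidase 2 (Rattus norvegicus), tested at 10 uM (a lower number here means a weaker effect, a higher number a stronger effect of the compound at the concentration tested), compound 1 gives 73%, while compound 2 gives 71%. Compound 2 holds the smaller of the two numbers, yet the gap to compound 1 lies within the usual scatter of this assay, so the two cannot be told apart on these data.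

Compound 3, `Cc1n[nH]c(C(=O)O)c1Cc1ccc(C#N)cc1`, is not yet measured. It differs from compound 2 in one place: cyano in place of trifluoromethyl on an aromatic carbon. No comparable change has been measured among the compounds shown, so nothing here indicates how large the effect will be or in which direction. A modest loss seems a fair expectation, though a step no larger than the scatter is also quite possible. The expected step of a number 13 percentage points lower from compound 2 to compound 3 (beyond the scatter) is therefore small to moderate and downward. Compound 3 is estimated to give 58% in this assay, within a range from 35% to 78%.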

Compound 3, a percentage reported as inhibition, at one concentration (the size of the read-out at that concentration, not a potency): 85%
Compound 3: the middle estimate sits 27 percentage points below what was measured, outside the stated range (above it).
By their numbers in this assay, from the lowest: compounds 2 and 1 (each within the scatter of the next); then compound 3.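

In this assay, among the compounds shown here, the swap of trifluoromethyl for cyano on an aromatic carbon, para to a large group, gives a number 14 percentage points higher from compound 2 to compound 3 (beyond the scatter), the first change at this place whose size and direction can be read. This shows that the read-out at this concentration responds to what sits at this position, and that here the group with fewer heavy atoms, which also counts as a hydrogen-bond acceptor, goes with the higher number. No measurement shown here explains why this swap raises the read-out.

This single pair cannot separate the two differences between the groups, the heavy-atom count and the hydrogen-bond acceptor, so neither can be credited with the rise on its own. The compounds shown also leave open how an amine, a carboxylic acid or a methoxy group at the same place would compare with cyano, and whether cyano would bring a similar step on a different substituted ring, such as the one in compound 1.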